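Changing the Terminal Amine at the End of a Side Chain

The source may hold more compounds than are shown below. What is called first, only, known or untested is meant among the compounds shown, and "the series" means these compounds.

compound 1 `CN1CCN(CCCOc2c(OCc3ccccc3)cc3oc(-c4ccccc4)cc(=O)c3c2O)CC1` — 2400 nM
compound 2 `COc1cc2oc(-c3ccccc3)cc(=O)c2c(O)c1OCCCN1CCCC1` — 4300 nM

Of the compounds shown here, two sharing the same core have been tested. In a functional assay on HepG2 cells (Homo sapiens) for antiproliferative activity, read by MTT assay, with a stated time of 48 h (a higher number here means a weaker inhibitor, a lower number a stronger inhibitor), compound 1 gives 2400 nM and compound 2 gives 4300 nM. The number for compound 2 is the higher of the two, but only by an amount that falls within the usual scatter of this assay, so the two compounds cannot be separated on these data. Compound 1 and compound 2 differ in more than one place, so no single change can be read from that pair.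

Compound 3 `COc1cc2oc(-c3ccccc3)cc(=O)c2c(O)c1OCCCN1CCN(C)CC1` is the next compound. It differs from compound 2 in one place: 4-methylpiperazin-1-yl in place of pyrrolidin-1-yl on a saturated chain carbon, three bonds along the chain from an oxygen on an aromatic ring. Among the measured compounds shown here, no measured pair isolates this change; compound 1 does carry the 4-methylpiperazin-1-yl group, but it also differs from compound 2 elsewhere. With nothing to anchor the size of the step, the expectation is a step of a 1.2-fold lower number from compound 2 to compound 3 (0.09 log units; within the scatter) in this assay, not beyond the scatter. Compound 3 is therefore estimated at 3500 nM, with a plausible range from 1500 nM to 8000 nM.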

Compound 3, half-maximal inhibitory concentration: 15100 nM
Estimate against measurement, compound 3: 4.3-fold (0.63 log units) below; measured number above the stated range.
By their numbers in this assay, from the lowest: compounds 1 and 2 (each within the scatter of the next); then compound 3.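

In this assay, the terminal amine now has a measured effect: 4-methylpiperazin-1-yl in place of pyrrolidin-1-yl, on a saturated chain carbon three bonds along the chain from an oxygen on an aromatic ring, gives a 3.5-fold higher number from compound 2 to compound 3 (0.55 log units; beyond the scatter) and so moves the number beyond the scatter. Carrying 4-methylpiperazin-1-yl does not by itself set the number, since a change elsewhere on the molecule, hydrogen in place of phenyl on a saturated chain carbon bound to an oxygen on an aromatic ring, gives a 6.3-fold higher number from compound 1 to compound 3 (0.80 log units; beyond the scatter) with that amine left in place. No supporting measurement is available to explain either step.

On these data alone, whether the amine swap would give a step of similar size with the phenyl group present remains open, since only the hydrogen-bearing pair isolates it. Also open, as far as these compounds go, is how other terminal amines, such as morpholin-4-yl or piperidin-1-yl, or a longer chain carrying either amine would compare in this assay.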